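Compound 3 and a phenylsulfonyl addition

The source may hold more compounds than are shown below. What is called first, only, known or untested is meant among the compounds shown, and "the series" means these compounds.

In a functional assay on SK-MEL-28 cells (Homo sapiens) for cytotoxicity, read by MTT assay, with a stated time of 3 days (on this read-out higher numbers stand for weaker inhibition and lower numbers for stronger inhibition), the measured compounds give these values:
- Compound 1 `N#Cc1c(Nc2nccs2)nc(SCc2nc3ccccc3[nH]2)nc1-c1ccccc1` gives 8.9 nM
- Compound 2 `N#Cc1c(NC(N)=O)nc(SCc2nc3ccccc3[nH]2)nc1-c1ccccc1` gives 4.8 nM
- Compound 3 `N#Cc1c(-c2ccccc2)nc(SCc2nc3ccccc3[nH]2)nc1N1CCNCC1` gives 2.6 nM

Compound 3 stands level with compound 2 and clear of compound 1. The steps of a 1.9-fold lower number from compound 1 to compound 2 (0.27 log units; within the scatter) and a 1.8-fold lower number from compound 2 to compound 3 (0.27 log units; within the scatter) are small, and the step of a 3.4-fold lower number from compound 1 to compound 3 (0.53 log units; beyond the scatter) is the only one beyond the scatter, so it sets the yardstick for size. Compound 4 `N#Cc1c(-c2ccccc2)nc(SCc2nc3ccccc3[nH]2)nc1N1CCN(S(=O)(=O)c2ccccc2)CC1` differs from compound 3 by phenylsulfonyl in place of hydrogen on an amine nitrogen in a ring and so carries phenylsulfonyl in place of hydrogen on an amine nitrogen in a ring. Within the data shown here, no measured step changes that nitrogen, so the guide is rough. In this assay a modest rise in the number, meaning weaker inhibition, is expected, with a 1.9-fold higher number from compound 3 to compound 4 (0.28 log units; within the scatter) as the estimate. Compound 4 is estimated at 5 nM with a range of 1.5 nM to 18 nM expected.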

Compound 4, half-maximal inhibitory concentration: 6.41 nM
Compound 4: middle estimate off by 1.3-fold (0.11 log units), on the low side; the range from low to high includes it.
By their numbers in this assay, from the lowest: compounds 3, 2, 4 and 1 (each within the scatter of the next, the first and the last beyond it).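

Compound 4 is the first compound shown with a change on the amine nitrogen in a ring, and adding phenylsulfonyl there gives a 2.5-fold higher number from compound 3 to compound 4 (0.39 log units; beyond the scatter). The change is beyond the scatter but modest, so this nitrogen can carry a group of 9 heavy atoms in place of hydrogen without losing inhibition in these cells. No available evidence explains the rise.

Going by these compounds, it remains open how much the phenyl ring and the sulfonyl each contribute. A methyl, an acetyl or a methanesulfonyl on that nitrogen could help separate them.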